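Shortening a selenium chain on two related cores

The compounds below may be only part of what the source reports. "The series", "measured", "known", "first", "only" and "open" are said of these compounds alone.

Compound 1 `CCCCC[Se]c1nc(NCc2ccccc2)c2ccccc2n1` and compound 3 `C[Se]c1nc(NCc2ccccc2)c2ccccc2n1` share one core, while compound 2 `CCCCC[Se]c1nc(N)c2cccnc2n1` and compound 4 `C[Se]c1nc(N)c2cccnc2n1` share another; the difference between the two cores is not broken down here. In an ADME assay on 184B5 cells (Homo sapiens) for cytotoxicity, read by MTT assay, with a stated time of 72 h (on this read-out higher numbers stand for weaker inhibition of growth and lower numbers for stronger inhibition of growth), compound 1 gives only a limit, > 100000 nM (the limit of > 100000 nM in this assay, at which 1 of the 3 values shown sits). Compound 3 reaches 12400 nM, so an at least 8.0-fold lower number from compound 1 to compound 3 (0.90 log units; beyond the scatter), the change being (hydrogen in place of butyl on a saturated chain carbon bound to a selenium atom). Compound 2 gives 40200 nM in this assay. Compound 4 carries the same change against compound 2, namely (hydrogen in place of butyl on a saturated chain carbon bound to a selenium atom). Because compound 3 moved from compound 1 by an at least 8.0-fold lower number from compound 1 to compound 3 (0.90 log units; beyond the scatter), a step of similar direction is expected here, though the limit at compound 1 leaves its full size open, so compound 4 is expected to sit at a 4.5-fold lower number from compound 2 to compound 4 (0.65 log units; beyond the scatter) from compound 2. Compound 4 is therefore estimated at 9000 nM, between 3000 nM and 30000 nM.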

Compound 4, concentration for total growth inhibition: 87200 nM
The estimate for compound 4 lay 9.7-fold (0.99 log units) below the measured number; measured number above the stated range.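

In this assay, shortening pentyl to methyl on the selenium atom gives a 2.2-fold higher number from compound 2 to compound 4 (0.34 log units; beyond the scatter). The same change therefore does not carry over from one core to the other in these two pairs, and its direction reverses: the same change on two cores in this assay, an at least 8.0-fold lower number (0.90 log units; beyond the scatter) from compound 1 to compound 3 and a 2.2-fold higher number (0.34 log units; beyond the scatter) from compound 2 to compound 4, at least 17-fold (1.24 log units) apart, beyond the scatter of two such steps. This does not show which part of the cores matters or how large the difference truly is, and compound 1 gives only a limit: the limit of > 100000 nM in this assay, at which 1 of the 4 values shown sits.

Two chain lengths say nothing about how the number moves with a chain of intermediate length, such as ethyl or propyl, or with a chain ending in an amine. As far as these compounds go, it also remains open whether a further core would behave like compound 1 and compound 3 or like compound 2 and compound 4.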